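Swapping an ester-bearing side chain for a small branched one

The source may hold more compounds than are shown below. What is called first, only, known or untested is meant among the compounds shown, and "the series" means these compounds.

Measured so far in a functional assay on the whole organism (Tail, strain ICR) with Mus musculus as the target, in the tail flick test, with a stated time of 150 min, at a dose of 25 umol/kg by the oral route; on this read-out lower numbers stand for a weaker effect and higher numbers for a stronger effect at the one dose given:
Compound 1 `CC(C)[C@H](NC(=O)CN(c1nc(Cl)nc2[nH]cnc12)C1CC1)C(=O)OCc1ccccc1` gives 17.9%.
Compound 2 `O=C(CN(c1nc(Cl)nc2[nH]cnc12)C1CC1)N[C@@H](CCC(=O)OCc1ccccc1)C(=O)OCc1ccccc1` gives 44.5%.
Compound 3 `O=C(OCc1ccccc1)[C@@H]1CCCN1C(=O)CN(c1ncnc2c1ncn2C1CCCCO1)C1CC1` gives 7.85%.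

Compound 2 stands highest of the three numbers; compound 1 lies nearest and compound 3 furthest, both beyond the scatter. Compound 4 `CC(C)C[C@H](NC(=O)CN(c1nc(Cl)nc2[nH]cnc12)C1CC1)C(=O)OCc1ccccc1` is the next step from compound 2. The change is isopropyl in place of (benzyloxycarbonyl)methyl on a saturated chain carbon, two bonds along the chain from an amide-type nitrogen and a carbonyl carbon.

Among the measured compounds shown here, only one measured step bears on this: a number 26.6 percentage points higher from compound 1 to compound 2 (beyond the scatter). There, a side chain carrying a benzyloxycarbonyl group replaced a plain isopropyl and the activity rose by a modest amount. The move to compound 4 removes the benzyloxycarbonyl-bearing part again and leaves a short branched chain, so the step is expected to run the other way, with a size near the earlier one. Compound 3 carries a different core and gives no guidance on this side chain.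

Compound 4 is therefore expected to give 22%, within 8% to 40%, a step of a number 22.5 percentage points lower from compound 2 to compound 4 (beyond the scatter).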

Compound 4, a percentage reported as activity, at one dose (the size of the read-out at that dose, not a potency): 5.26%
Estimate against measurement, compound 4: 16.7 percentage points above; measured number below the stated range.
By their numbers in this assay, from the lowest: compounds 4 and 3 (each within the scatter of the next); then compound 1; then compound 2.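

In this assay, replacing the 2-(benzyloxycarbonyl)ethyl chain with isobutyl gives a number 39.2 percentage points lower from compound 2 to compound 4 (beyond the scatter), a large drop that shows a second small chain also falling well short of compound 2. The two small chains are not interchangeable at this saturated chain carbon, since isobutyl in place of isopropyl gives a number 12.6 percentage points lower from compound 1 to compound 4 (beyond the scatter), so the number responds to more than whether the benzyloxycarbonyl group is present. No measurement shown here explains either step.

The compounds shown leave open whether compound 2 owes its higher number to the whole 2-(benzyloxycarbonyl)ethyl chain, or whether a free carboxylic acid at the end of that chain would serve as well. They also leave open how an amine at the chain end, or a longer plain carbon chain, would compare.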